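Cytotoxicity of a Hydrazone Series: Estimating Compound 4

This account rests on a few compounds, and the source may have more. Where it says the series, first, only, none or still open, it means among the compounds named here.

Of the compounds shown here, three sharing one core have been measured. Compound 1 `O=C(COc1cccc2ccccc12)N/N=C/c1c(O)ccc2ccccc12` gives 2.12 ug/mL in an ADME assay on MT4 cells (Homo sapiens) for cytotoxicity, read by MTT assay, with a stated time of 4 days; a higher number here means that more compound is tolerated, a lower number that less compound is tolerated. Compound 2 `O=C(COc1cccc2ccccc12)N/N=C/c1ccccc1[N+](=O)[O-]` gives 12.2 ug/mL in this assay, and compound 3 `O=C(COc1cccc2ccccc12)N/N=C/c1ccccc1Br` gives 11.4 ug/mL in this assay. Compound 3 thus holds the second highest of the three numbers: compound 2 lies nearest, within the scatter, while compound 1 gives a number well below it.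

Among the measured compounds shown here, the single measured step, a 1.1-fold lower number from compound 2 to compound 3 (0.03 log units; within the scatter), swaps bromo for nitro on an aromatic carbon and leaves the number essentially unchanged.

Compound 4 `O=C(COc1cccc2ccccc12)N/N=C/C=C/c1ccccc1` is not yet measured. It differs from compound 3 in one place: 2-phenylethenyl in place of 2-bromophenyl on a carbon with a double bond to nitrogen. For the measured compounds named here, no measured step replaces the whole ring-bearing group in this way, so that step bears only loosely, showing that a change at the aromatic ring can pass without effect. Compound 1, with a different group on the carbon with a double bond to nitrogen, shows that such a change can also move the number, but no step is shown between compound 1 and compound 3. Compound 4 is therefore expected to stay close, with a 1.1-fold lower number from compound 3 to compound 4 (0.06 log units; within the scatter) within the scatter. Compound 4 is estimated at 10 ug/mL, between 4 ug/mL and 25 ug/mL.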

Compound 4, half-maximal cytotoxic concentration: 82.7 ug/mL
Beside the measured number, compound 4's estimate is 8.3-fold (0.92 log units) below it, and the stated range ends below it.
By their numbers in this assay, from the lowest: compound 1; then compounds 3 and 2 (each within the scatter of the next); then compound 4.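

In this assay, placing 2-phenylethenyl where 2-bromophenyl stood, on a carbon with a double bond to nitrogen, gives a 7.3-fold higher number from compound 3 to compound 4 (0.86 log units; beyond the scatter) and so more compound is tolerated. Among the compounds shown here, the earlier step from compound 2 to compound 3 changed only one group on the aromatic ring and stayed within the scatter, whereas this change replaces the whole ring-bearing group, and it shows that such a replacement at this place can raise the number beyond the scatter. The step comes with no measurement that accounts for the rise.

The change also does two things at once, since the bromine leaves while a double bond outside the aromatic ring enters, and a plain phenyl group or a saturated 2-phenylethyl chain at this place would help tell those two apart. Going by these compounds, it also remains open whether the higher number would hold with an amine or a carboxylic acid on the aromatic ring of the 2-phenylethenyl group, or with a longer chain carrying that ring.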